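Exchanging a side chain: from compound 3 to compound 4

This account rests on a few compounds, and the source may have more. Where it says the series, first, only, none or still open, it means among the compounds named here.

Measured in a functional assay on U-373MG ATCC cells (Homo sapiens) for inhibition, read by MTT assay, with a stated time of 72 h; a lower number here means a stronger inhibitor of growth, a higher number a weaker inhibitor of growth:
Compound 1 `CCOC(=O)/C(C)=C/C1=CC[C@H]2C(C)(C)CCC[C@]2(C)[C@H]1C=O`: 37000 nM
Compound 2 `CC(C)(C)OC(=O)/C=C/C1=CC[C@H]2C(C)(C)CCC[C@]2(C)[C@H]1C=O`: 40000 nM
Compound 3 `COC(=O)/C=C/C=C/C1=CC[C@H]2C(C)(C)CCC[C@]2(C)[C@H]1C=O`: 27000 nM

Compound 3 stands within the scatter of both compound 1 and compound 2, so the three values cannot be ranked. Compound 4 `C#CCCCOC(=O)/C=C/C1=CC[C@H]2C(C)(C)CCC[C@]2(C)[C@H]1C=O` has not yet been measured. Its difference from compound 3 is ((pent-4-yn-1-yl)oxy)carbonyl in place of 2-(methoxycarbonyl)ethenyl on a double-bonded chain carbon bound to a double-bonded chain carbon. For the measured compounds named here, one measured step bears on this place, a 1.5-fold lower number from compound 2 to compound 3 (0.17 log units; within the scatter), and it stayed within the scatter. Going by the values given here, no measured compound carries the ((pent-4-yn-1-yl)oxy)carbonyl group. No change beyond the scatter is therefore expected in this assay. The estimated step is a 1.1-fold higher number from compound 3 to compound 4 (0.05 log units; within the scatter). For compound 4 the expected value is 30000 nM, with an estimated range from 14000 nM to 60000 nM.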

Compound 4, concentration for 50% growth inhibition: 35000 nM
Estimate against measurement, compound 4: 1.2-fold (0.07 log units) below, and the stated range covers the measured number.
By their numbers in this assay, from the lowest: compounds 3, 4, 1 and 2 (each within the scatter of the next).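

In this assay, for the compounds shown here, pent-4-yn-1-yl in place of tert-butyl on an oxygen next to a carbonyl group gives a 1.1-fold lower number from compound 2 to compound 4 (0.06 log units; within the scatter), the first measured exchange of this alkyl group alone. Against the longer unsaturated ester chain, the ((pent-4-yn-1-yl)oxy)carbonyl group gives a 1.3-fold higher number from compound 3 to compound 4 (0.11 log units; within the scatter), so a chain ending in a triple bond also leaves the number within the scatter. Nothing available explains these results. The compounds shown leave open whether a carboxylic acid or an amine at this place would move the number beyond the scatter.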